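The source may report more compounds than this note shows. Statements on the series, on what has been measured and on what is new or still open speak of the compounds shown alone.

Compound 1 `Cc1cc(Nc2cc(N3CCN(C)CC3)nc(Nc3ccc([N+](=O)[O-])cc3)n2)n[nH]1`: 43.3 nM
Compound 2 `Cc1cc(Nc2cc(N3CCN(C)CC3)nc(Nc3cccc([N+](=O)[O-])c3)n2)n[nH]1`: 25.2 nM
Compound 3 `Cc1cc(Nc2cc(N3CCN(C)CC3)nc(Nc3cccc(Cl)c3)n2)n[nH]1`: 21.7 nM

These three values come from a functional assay on U-937 cells (Homo sapiens) for antiproliferative activity, read by CCK-8 assay, with a stated time of 72 h; on this read-out higher numbers stand for weaker inhibition and lower numbers for stronger inhibition. Compound 3, at 21.7 nM, lies within the scatter of both compound 1 and compound 2, so the three compounds cannot be ranked on these numbers.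

Compound 4 `COc1ccc(Nc2nc(Nc3cc(C)[nH]n3)cc(N3CCN(C)CC3)n2)cc1` has not yet been measured. It differs from compound 3 in one place, with 4-methoxyphenyl in place of 3-chlorophenyl on a nitrogen on an aromatic ring.

Among the compounds with values here, three measured steps bear on this change. Two replace the group on that same nitrogen, giving a 1.7-fold lower number from compound 1 to compound 2 (0.24 log units; within the scatter) and a 2.0-fold lower number from compound 1 to compound 3 (0.30 log units; within the scatter). The third, chloro in place of nitro on an aromatic carbon, gives a 1.2-fold lower number from compound 2 to compound 3 (0.06 log units; within the scatter). Within the data shown here, all three stay within the scatter, although none of the measured compounds carries a methoxy group.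

A step beyond the scatter is therefore not expected in this assay. The expected step is a 1.6-fold higher number from compound 3 to compound 4 (0.21 log units; within the scatter). For compound 4 the estimated value is 35 nM, with an expected range of 12 nM to 110 nM.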

Compound 4, half-maximal inhibitory concentration: 92.3 nM
The estimate for compound 4 lay 2.6-fold (0.42 log units) below the measured number; the range from low to high includes it.
By their numbers in this assay, from the lowest: compounds 3, 2 and 1 (each within the scatter of the next); then compound 4.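

In this assay the group on this nitrogen now separates compounds, which none of the earlier changes there did: 4-methoxyphenyl gives a 4.3-fold higher number from compound 3 to compound 4 (0.63 log units; beyond the scatter) and a 3.7-fold higher number from compound 2 to compound 4 (0.56 log units; beyond the scatter) and also a 2.1-fold higher number from compound 1 to compound 4 (0.33 log units; beyond the scatter) in a comparison of two groups with the same ring placement in their names. All three steps lie beyond the scatter but stay modest, and compound 4 is the only one of the four set apart from each of the others. The data shown offer no measurement that explains this rise.

Still open, as far as these compounds go, is whether the rise goes with the methoxy group itself or with its place on the ring: a 3-methoxyphenyl or a 4-chlorophenyl group would separate the two. From the compounds shown here alone, how a plain phenyl or a 4-aminophenyl group on this nitrogen would compare also remains unknown.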